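The compounds below may be only part of what the source reports. "The series", "measured", "known", "first", "only" and "open" are said of these compounds alone.

Compound 1 `O=C(Nc1cccc(-c2oc3cc(-c4ccc(F)cc4)ccc3c(=O)c2O)c1)c1ccc(F)cc1` gives 9280 nM in a functional assay on HepG2 cells (Homo sapiens) for antiproliferative activity, read by CCK-8 assay, with a stated time of 72 h (a higher number here means a weaker inhibitor, a lower number a stronger inhibitor), the lowest of the three numbers measured, though the other two sit within the scatter of it: compound 2 `O=C(Nc1cccc(-c2oc3cc(-c4ccc(F)cc4)ccc3c(=O)c2O)c1)c1ccc(Cl)cc1` gives 11000 nM and compound 3 `Cc1cccc(C(=O)Nc2cccc(-c3oc4cc(-c5ccc(F)cc5)ccc4c(=O)c3O)c2)c1` gives 13500 nM. The steps between them are small: a 1.2-fold higher number from compound 1 to compound 2 (0.07 log units; within the scatter), a 1.5-fold higher number from compound 1 to compound 3 (0.16 log units; within the scatter) and a 1.2-fold higher number from compound 2 to compound 3 (0.09 log units; within the scatter). Compound 4 `COc1cc(OC)cc(C(=O)Nc2cccc(-c3oc4cc(-c5ccc(F)cc5)ccc4c(=O)c3O)c2)c1` differs from compound 1 in one place: 3,5-dimethoxyphenyl in place of 4-fluorophenyl on a carbonyl carbon. Within the data shown here, the steps that bear on this change are those exchanging the aryl group on the carbonyl carbon, a 1.5-fold higher number from compound 1 to compound 3 (0.16 log units; within the scatter) and a 1.2-fold higher number from compound 2 to compound 3 (0.09 log units; within the scatter), both within the scatter, so no step beyond the scatter is expected in this assay. Compound 4 is therefore estimated at 12000 nM, between 6000 nM and 25000 nM, an expected step of a 1.3-fold higher number from compound 1 to compound 4 (0.11 log units; within the scatter).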

Compound 4, half-maximal inhibitory concentration: 23500 nM
The estimate for compound 4 lay 2.0-fold (0.29 log units) below the measured number, within the range that was stated.
By their numbers in this assay, from the lowest: compounds 1, 2, 3 and 4 (each within the scatter of the next, the first and the last beyond it).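

With 3,5-dimethoxyphenyl on the carbonyl carbon, this position shows its first steps beyond the scatter in this assay with a 2.5-fold higher number from compound 1 to compound 4 (0.40 log units; beyond the scatter) and a 2.1-fold higher number from compound 2 to compound 4 (0.33 log units; beyond the scatter) both modest, while a 1.7-fold higher number from compound 3 to compound 4 (0.24 log units; within the scatter) stays within it. The aryl group here can therefore shift the number, though only slightly so far. No evidence is available on what lies behind this change. The compounds shown leave open whether an amine or a carboxylic acid on this aryl ring would move the number further, and in which direction.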